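Quinoline ureas: cytotoxicity limits and a tert-butyl analogue

The compounds below may be only part of what the source reports. "The series", "measured", "known", "first", "only" and "open" are said of these compounds alone.

Measured compounds:
compound 1, `Cc1cc(NC(=O)Nc2ncccc2C)c2ccccc2n1`: > 25000 nM
compound 2, `Cc1cc(NC(=O)Nc2ccc(O)cc2)c2ccccc2n1`: > 25000 nM
compound 3, `Cc1cc(NC(=O)Nc2ccccc2N)c2ccccc2n1`: > 25000 nM

In an ADME assay on HEK293 cells (Homo sapiens) for cytotoxicity, with a stated time of 72 h (a higher number here means that more compound is needed for the effect, a lower number that less compound is needed), compound 1 gives > 25000 nM, which is a limit of the assay and not a number. Compound 2 gives a limit in this assay as well, > 25000 nM. Compound 3 gives a limit too, > 25000 nM. Compound 2 therefore stands at the same limit as the other two, and no ordering among the three can be read from this assay.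

The measured steps are accordingly unreadable: a step that the two limits leave unreadable from compound 1 to compound 2, a step that the two limits leave unreadable from compound 1 to compound 3 and a step that the two limits leave unreadable from compound 2 to compound 3. Among the compounds with values here, the only evidence the series offers is the limit of > 25000 nM in this assay, at which 3 of the 3 values shown sit.

Compound 4, `Cc1cc(NC(=O)Nc2ccc(C(C)(C)C)cc2)c2ccccc2n1`, is not yet measured. Its change from compound 2 is tert-butyl in place of hydroxy on an aromatic carbon. Within the data shown here, no measured step bears on this change, and none of the measured steps has a readable size. Because (the limit of > 25000 nM in this assay, at which 3 of the 3 values shown sit), compound 4 is expected to sit at or close to the limit as well, with no step beyond the scatter. The expected step is a step that the limit leaves unreadable from compound 2 to compound 4. For compound 4 the estimate is 30000 nM, with a range from 10000 nM to 60000 nM.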

Compound 4, half-maximal effective concentration: > 25000 nM
Compound 4 ended at the assay's limit; the forecaster's own chance of this, stated with the estimate: 75%; the middle value lies beyond the limit too.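

The step from compound 2 to compound 4 cannot be read, as both values are limits and not numbers: the limit of > 25000 nM in this assay, at which 4 of the 4 values shown sit.

The compounds shown leave open at what concentration any of compound 1, compound 2, compound 3 or compound 4 reaches the half-maximal effect in this assay, and whether any of these changes alters it.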